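Exchanging one small ring for another on the shared core

The compounds below may be only part of what the source reports. "The series", "measured", "known", "first", "only" and "open" are said of these compounds alone.

Of the compounds shown here, three on a shared core have been tested in a physicochemical assay for solubility, using the shake flask method, in simulated intestinal fluid, measured as kinetic solubility, with a stated time of 20 h, at pH 6.5; a lower number here means a less soluble compound, a higher number a more soluble compound. Compound 1 `Fc1ccc(-c2nc3cnc(Nc4ccc(C(F)(F)F)cn4)cc3[nH]2)cc1F` reports >= 50000 nM, which is a limit of the assay and not a number. That limit leaves two steps open, a step that the limit leaves unreadable from compound 1 to compound 2 and a step that the limit leaves unreadable from compound 1 to compound 3. Compound 2 `FC(F)(F)c1ccc(Nc2cc3[nH]c(C4CCOCC4)nc3cn2)nc1` gives 168000 nM. Compound 3 `CC1(c2nc3cnc(Nc4ccc(C(F)(F)F)cn4)cc3[nH]2)CC1` gives 179000 nM, which places it level with compound 2.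

Compound 4 `FC1(F)CC(c2nc3cnc(Nc4ccc(C(F)(F)F)cn4)cc3[nH]2)C1` carries 3,3-difluorocyclobutyl in place of 1-methylcyclopropyl on an aromatic carbon. Among the measured compounds shown here, the only readable step, a 1.1-fold higher number from compound 2 to compound 3 (0.03 log units; within the scatter), exchanged oxan-4-yl for 1-methylcyclopropyl at this same place. For the measured compounds named here, no measured step tests the entering group directly, so the expectation rests on that single comparison. A small drop that stays within the scatter is expected, the estimated change being a 1.3-fold lower number from compound 3 to compound 4 (0.11 log units; within the scatter). Compound 4 is estimated at 140000 nM, with an expected range of 50000 nM to 300000 nM.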

Compound 4, solubility: 161000 nM
Compound 4: middle estimate off by 1.2-fold (0.06 log units), on the low side; measured number inside the range.
By their numbers in this assay, from the lowest: compounds 4, 2 and 3 (each within the scatter of the next).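

In this assay, 3,3-difluorocyclobutyl on this aromatic carbon, between two ring nitrogen atoms, gives no separation from either earlier group: a 1.1-fold lower number from compound 3 to compound 4 (0.05 log units; within the scatter) and a 1.0-fold lower number from compound 2 to compound 4 (0.02 log units; within the scatter). Compounds 2, 3 and 4 therefore stand level within the scatter, although they carry a six-membered ring with oxygen, a three-membered ring and a four-membered ring with two fluorine atoms, so neither ring size nor the presence of these atoms separates them here. The steps from compound 1 to the other compounds cannot be read because its value is a limit of the assay and not a number: the limit of >= 50000 nM in this assay, at which 1 of the 4 values shown sits.

The compounds shown do not tell whether an amine or a longer carbon chain at this place would stay level with compounds 2, 3 and 4. They also leave open how the 3,4-difluorophenyl of compound 1 truly compares with these three rings.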